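Replacing the aryl amine substituent: from compound 3 to compound 4

The source may hold more compounds than are shown below. What is called first, only, known or untested is meant among the compounds shown, and "the series" means these compounds.

Compound 1, `COc1cc(NC(=O)Nc2cc(Nc3ccc(OC)c(C)c3)ncn2)cc(OC)c1`: in a functional assay on NCI-H520 cells (Homo sapiens) for inhibition, read by MTT assay, with a stated time of 48 h, tested at 10 uM (a higher number here means more inhibition at the concentration tested (going by the name of the read-out), a lower number less inhibition), compound 1 gives 13.5%.
Compound 2, `COc1cc(NC(=O)Nc2cc(Nc3ccc(C)c(F)c3)ncn2)cc(OC)c1`: in this assay compound 2 gives 30.6%.
Compound 3, `COc1cc(NC(=O)Nc2cc(Nc3ccc(Br)cc3OC)ncn2)cc(OC)c1`: in this assay compound 3 gives 36.1%.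

Compound 3 holds the highest of the three numbers. Its nearest neighbour is compound 2, and the gap between them, a number 5.5 percentage points higher from compound 2 to compound 3 (within the scatter), lies within the scatter, so the two cannot be ordered. The gap to compound 1, a number 22.6 percentage points higher from compound 1 to compound 3 (beyond the scatter), is beyond the scatter.

Compound 4, `CCc1ccc(Nc2cc(NC(=O)Nc3cc(OC)cc(OC)c3)ncn2)cc1`, is not yet measured. Compared with compound 3 it carries 4-ethylphenyl in place of 4-bromo-2-methoxyphenyl on a nitrogen on an aromatic ring.

All three measured steps change the aryl group on the same nitrogen. Two were modest and beyond the scatter, a number 17.1 percentage points higher from compound 1 to compound 2 (beyond the scatter) and a number 22.6 percentage points higher from compound 1 to compound 3 (beyond the scatter), while a number 5.5 percentage points higher from compound 2 to compound 3 (within the scatter) stayed within it. For the measured compounds named here, exchanging this group has therefore moved the number by modest amounts, without any one direction emerging from only three compounds. For compound 4 the step is expected to be about a number 8.1 percentage points lower from compound 3 to compound 4 (within the scatter), a modest fall that may well lie within the scatter, because compound 2, which likewise has no acceptor in this aryl group, gives 30.6%. Compound 4 is thus estimated at 28%, in the range 12% to 45%.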

Compound 4, a percentage reported as inhibition, at one concentration (the size of the read-out at that concentration, not a potency): 23.5%
For compound 4 the middle estimate is 4.5 percentage points above the measured one; measured number inside the range.
By their numbers in this assay, from the lowest: compounds 1, 4, 2 and 3 (each within the scatter of the next, the first and the last beyond it).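

In this assay the exchange of 4-bromo-2-methoxyphenyl for 4-ethylphenyl on this nitrogen gives a number 12.6 percentage points lower from compound 3 to compound 4 (beyond the scatter) and so sets compound 4 apart from compound 3 by more than the usual scatter of repeated measurements. Against the other two aryl groups the result is a number 7.1 percentage points lower from compound 2 to compound 4 (within the scatter) and a number 10 percentage points higher from compound 1 to compound 4 (within the scatter) and so compound 4 cannot be ordered against either of them, even though compound 1 and compound 2 themselves lie apart beyond the scatter. The position therefore now reads as one graded spread rather than two separate levels, and an aryl group of carbon only, with neither oxygen nor halogen, falls inside the span of the other three.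

From the compounds shown here alone, the step to compound 4 removes the bromine and the methoxy together, so it remains open which of the two matters, and how a 4-bromophenyl group, or an aryl group carrying an amine or a carboxylic acid, would read at this nitrogen. Nothing available here gives a reason for any of these differences.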